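The compounds below may be only part of what the source reports. "The series", "measured", "known", "first", "only" and "open" are said of these compounds alone.

Measured compounds in a functional assay on thoracic aorta for inhibition of Voltage-gated L-type calcium channel (Rattus norvegicus); a higher number here means a weaker inhibitor, a lower number a stronger inhibitor:
compound 1, `CC1=NC(C)=C(C(=O)O)C(c2cccc(I)c2)/C1=C(\O)OC/C=C/c1ccccc1`, gives 13 nM
compound 2, `CC1=NC(C)=C(C(=O)O)C(c2cccc(Cl)c2)/C1=C(\O)OC/C=C/C1CCCCC1`, gives 3.7 nM

Compound 2 stands at the lowest of the two numbers in this assay. Its nearest neighbour is compound 1, whose number lies above it by an amount beyond the usual scatter. Among the compounds with values here, no pair of measured compounds differs in only one place, so no measured single step exists within this small set to anchor the next change.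

Compound 3 is `CC1=NC(C)=C(C(=O)O)C(c2cccc(Cl)c2)/C1=C(\O)OCC(=O)Nc1ccccc1`. Its difference from compound 2 is phenylcarbamoyl in place of 2-cyclohexylethenyl on a saturated chain carbon bound to an oxygen on an unsaturated carbon. Both measured compounds carry a hydrocarbon group on the oxygen in question, one with a benzene ring and one with a cyclohexane ring, and the group that enters in compound 3 resembles neither; the series therefore offers no direct guide to the size of this step, and the estimate below rests on the two measured values alone and on the weight of the change.

Expected is a step upward in this assay, an 8.1-fold higher number from compound 2 to compound 3 (0.91 log units; beyond the scatter), beyond the scatter. Compound 3 is estimated at 30 nM, with a range from 6 nM to 150 nM.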

Compound 3, half-maximal inhibitory concentration: 50 nM
Compound 3: the middle estimate sits 1.7-fold (0.22 log units) below what was measured, within the range that was stated.
By their numbers in this assay, from the lowest: compound 2; then compound 1; then compound 3.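

In this assay, within the data shown here, the saturated chain carbon bound to an oxygen on an unsaturated carbon proves sensitive to the group it carries: phenylcarbamoyl in place of 2-cyclohexylethenyl gives a 14-fold higher number from compound 2 to compound 3 (1.13 log units; beyond the scatter), and this is the first comparison in which only one place differs. Among these compounds, the change is compound in nature, since a six-membered non-aromatic ring gives way to an aromatic one while the carbon-carbon double bond of the chain gives way to a carbonyl with an amide hydrogen, so the single step cannot assign its size to any one of these features. No accompanying measurement bears on this step, and the data therefore offer no account of its size.

The compounds shown leave open whether the step follows the amide link or the aromatic ring, a question that cyclohexylcarbamoyl at this place would separate from phenylcarbamoyl. Also open, from the compounds shown here alone, is whether the double bond of 2-cyclohexylethenyl matters at all, which a saturated 2-cyclohexylethyl group would address.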